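Tetrazolylacetamide series: from dichlorophenyl to trifluoromethylphenyl

The source may hold more compounds than are shown below. What is called first, only, known or untested is meant among the compounds shown, and "the series" means these compounds.

Three compounds of the series have been characterised in an assay on HEK293 cells for activation of Kir3.1/Kir3.2 (Homo sapiens), read by thallium flux; on this read-out higher numbers stand for an effect only at larger amounts of compound and lower numbers for an effect already at smaller amounts. Compound 1 `O=C(Cn1nnc(-c2ccccc2)n1)Nc1cc(C2(C(F)(F)F)CC2)nn1C1CCCCC1` is reported in this assay as "not active" (no number reported). Compound 2 `Cc1nc(NC(=O)Cn2nnc(-c3ccccc3)n2)n(-c2ccccc2)n1` is likewise reported in this assay as "not active" (no number reported). For the measured compounds named here, compound 3 `Cc1cc(NC(=O)Cn2nnc(-c3cc(Cl)cc(Cl)c3)n2)n(C2CCCCC2)n1` is the one member with a number: in this assay compound 3 gives 980 nM, so it stands as the only quantified entry, with the two others recorded without a value.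

Compound 4 `Cc1cc(NC(=O)Cn2nnc(-c3ccc(C(F)(F)F)cc3)n2)n(C2CCCCC2)n1` is the next entry to be measured in this assay. It differs from compound 3 in one place: 4-(trifluoromethyl)phenyl in place of 3,5-dichlorophenyl on an aromatic carbon. Going by the values given here, no pair of measured compounds shows this kind of change, so there is no internal step to lean on; the expectation rests on compound 3 alone.

The estimate for compound 4 assumes a step from compound 3 of about a 1.6-fold higher number from compound 3 to compound 4 (0.21 log units; within the scatter) in this assay, a modest weakening that may still fall within the scatter. Compound 4 is therefore expected to give about 1600 nM in this assay, within a range of 500 nM to 5000 nM.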

Compound 4, half-maximal effective concentration: 241 nM
For compound 4 the middle estimate is 6.6-fold (0.82 log units) above the measured one; the measured number lies below the stated range.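

In this assay, the group on the aromatic carbon of the five-membered aromatic ring with 4 nitrogen now has its first readable step: 4-(trifluoromethyl)phenyl in place of 3,5-dichlorophenyl gives a 4.1-fold lower number from compound 3 to compound 4 (0.61 log units; beyond the scatter), beyond the usual scatter. A measurable effect at this position therefore does not depend on 3,5-dichlorophenyl, and the number responds to the substitution of this phenyl ring while the rest of the molecule stays the same. Nothing at hand explains the step.

The compounds shown leave open whether the trifluoromethyl group itself carries the step, or whether a nitrile or a methoxy group in its place would give a similar number. Also open, as far as these compounds go, is how an unsubstituted phenyl behaves on the core of compound 3, as compound 1 and compound 2 differ from it in more than one place.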